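One Swap, Little Expected Change in Cytotoxicity

The compounds below may be only part of what the source reports. "The series", "measured", "known", "first", "only" and "open" are said of these compounds alone.

Compound 1 `COC(=O)c1ccc(C(=O)NNc2c(Br)cccc2Br)cc1`: 87600 nM
Compound 2 `O=C(NNc1c(Br)cccc1Br)c1ccc(-c2ccccc2)cc1`: 84100 nM
Compound 3 `O=C(NNc1c(Br)cccc1Br)c1ccc(O)cc1`: not yet measured

Within the data shown here, in a toxicity assay on MDCK cells (Canis lupus familiaris) for cytotoxicity, read by CCK-8 assay, with a stated time of 48 h (on this read-out lower numbers stand for higher toxicity in this test and higher numbers for lower toxicity in this test), compound 2 gives 84100 nM, within the usual scatter of compound 1, the only other measured compound. Compound 3 has hydroxy in place of phenyl on an aromatic carbon. Among the measured compounds shown here, only one measured step bears on this: a 1.0-fold lower number from compound 1 to compound 2 (0.02 log units; within the scatter). It also exchanged a group on an aromatic carbon, but it is a single example and hydroxy was not part of it. No step beyond the scatter is therefore expected in this assay. The estimated step is a 1.1-fold lower number from compound 2 to compound 3 (0.02 log units; within the scatter). For compound 3, the expected value is 80000 nM, with an estimated range of 35000 nM to 170000 nM.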

Compound 3, half-maximal cytotoxic concentration: > 100000 nM
Compound 3: only a limit was reported (the forecaster's own chance of this, stated with the estimate: 15%); middle value at least 1.2-fold (0.09 log units) from the limit.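

In this assay compound 3 gives > 100000 nM as a limit of the assay, not a number. Hydroxy in place of phenyl gives an at least 1.1-fold higher number from compound 2 to compound 3 (0.07 log units; that floor lies within the scatter) and hydroxy in place of methoxycarbonyl gives an at least 1.1-fold higher number from compound 1 to compound 3 (0.05 log units; that floor lies within the scatter) with both floors within the scatter. So this small group on the aromatic carbon para to a large group brings no sign of higher toxicity, while the true size of the step stays unreadable: the limit of > 100000 nM in this assay, at which 1 of the 3 values shown sits.

From the compounds shown here alone, whether an amine or a carboxylic acid at this place would match hydroxy remains open. So does whether any group here can move the number beyond the scatter.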